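Chloro for Hydroxy on the Aryl Ketone Ring

The compounds below may be only part of what the source reports. "The series", "measured", "known", "first", "only" and "open" are said of these compounds alone.

Compound 1 `COc1ccc(C(=O)/C=C/c2cc3ccccc3[nH]c2=O)cc1`: 3290 nM
Compound 2 `O=C(/C=C/c1cc2ccccc2[nH]c1=O)c1ccc(O)cc1`: 2310 nM

Of the compounds shown here, two have been tested in a functional assay on MDA-MB-231 cells (Homo sapiens) for cytotoxicity, read by sulforhodamine B assay, with a stated time of 24 h; on this read-out higher numbers stand for weaker inhibition of growth and lower numbers for stronger inhibition of growth. Compound 1 gives 3290 nM, and compound 2 gives 2310 nM. Among the measured compounds shown here, the single measured step, a 1.4-fold lower number from compound 1 to compound 2 (0.15 log units; within the scatter), is within the scatter, so compound 2, although it holds the lowest of the two numbers, cannot be told apart from compound 1 on these data.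

Compound 3 `O=C(/C=C/c1cc2ccccc2[nH]c1=O)c1ccc(Cl)cc1` differs from compound 2 by chloro in place of hydroxy on an aromatic carbon. For the measured compounds named here, no measured step exchanges hydroxy for chloro. Going by the values given here, the only step on record, a 1.4-fold lower number from compound 1 to compound 2 (0.15 log units; within the scatter), alters the group on that same oxygen and stays within the scatter; it gives no ground for expecting a step beyond the scatter in this assay for compound 3. Compound 3 is therefore expected to give about 2000 nM, with a range from 700 nM to 6000 nM. For compound 3 the expected step, a 1.2-fold lower number from compound 2 to compound 3 (0.06 log units; within the scatter), stays within the scatter.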

Compound 3, concentration for 50% growth inhibition: 6160 nM
Beside the measured number, compound 3's estimate is 3.1-fold (0.49 log units) below it, outside the stated range (above it).
By their numbers in this assay, from the lowest: compounds 2, 1 and 3 (each within the scatter of the next, the first and the last beyond it).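

This position now shows its first step beyond the scatter in this assay: on an aromatic carbon para to a large group, the exchange of hydroxy for chloro gives a 2.7-fold higher number from compound 2 to compound 3 (0.43 log units; beyond the scatter), a modest step. The exchange of methoxy for chloro gives a 1.9-fold higher number from compound 1 to compound 3 (0.27 log units; within the scatter), which stays within the scatter, so at this position the assay separates chloro from hydroxy but not chloro from methoxy. Nothing measured here explains the step from hydroxy to chloro.

The compounds shown leave open whether an amine, a carboxylic acid or a bromo group at this position would read closer to hydroxy or to chloro. They also leave open whether the same exchange elsewhere on this ring would give a step of similar size.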